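The compounds below may be only part of what the source reports. "The series", "measured", "known", "first", "only" and "open" are said of these compounds alone.

In an ADME assay on HEK293 cells (Homo sapiens) for cytotoxicity, read by ATP content, with a stated time of 6 h (on this read-out higher numbers stand for lower toxicity in this test and lower numbers for higher toxicity in this test), compound 3 (`Cc1cnc(CNc2nc(N)nc3ccn(Cc4ccccn4)c23)s1`) gives > 24000 nM as a limit of the assay, not a number. Compound 1 (`COCCNc1nc(N)nc2ccn(Cc3ccccn3)c12`) gives > 24000 nM as a limit too. Compound 2 (`COCCCNc1nc(N)nc2ccn(Cc3ccccn3)c12`) gives > 24000 nM as a limit too. Among the measured compounds shown here, the series so far stands at the limit of > 24000 nM in this assay, at which 3 of the 3 values shown sit, and compound 3 has no rank within it.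

Compound 4 (`Cc1cc(CNc2nc(N)nc3ccn(Cc4ccccn4)c23)on1`) differs from compound 3 in one place. The change is 3-methyl-1,2-oxazol-5-yl in place of 5-methyl-1,3-thiazol-2-yl on a saturated chain carbon bound to a nitrogen on an aromatic ring and in words it puts 3-methyl-1,2-oxazol-5-yl in place of 5-methyl-1,3-thiazol-2-yl on a saturated chain carbon bound to a nitrogen on an aromatic ring.

For the measured compounds named here, three measured steps bear on this change, and none has a readable size: a step that the two limits leave unreadable from compound 1 to compound 2 and a step that the two limits leave unreadable from compound 1 to compound 3 and a step that the two limits leave unreadable from compound 2 to compound 3 all join compounds at the same limit. They give no direction and no magnitude to carry over. For compound 3 the starting point remains > 24000 nM as a limit, and no step beyond the scatter is expected in this assay in either direction. The estimated step is a number no higher from compound 3 to compound 4 (the limit leaves the size open) and a further limit would leave it unreadable. Compound 4 is estimated at 24000 nM with an expected range from 14000 nM to 40000 nM and another limit is the likeliest report.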

Compound 4, half-maximal cytotoxic concentration: > 24000 nM
Compound 4 ended at the assay's limit; the forecaster's own chance of this, stated with the estimate: 85%; the middle value sits exactly at the limit.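

No step can be read in this assay from compound 3, compound 2 or compound 1 to compound 4, and all four compounds stand at the same limit: the limit of > 24000 nM in this assay, at which 4 of the 4 values shown sit.

The compounds shown leave open how far any of the four lies beyond that limit, and whether exchanging the group on the saturated chain carbon changes the read-out at all.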